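Swapping methoxy for nitro on an unmeasured compound

The compounds below may be only part of what the source reports. "The series", "measured", "known", "first", "only" and "open" are said of these compounds alone.

compound 1 `Cc1nn(-c2ccccc2)c(Oc2ccc(-c3nc4cc([N+](=O)[O-])ccc4[nH]3)cc2)c1/C=N/Nc1ccccc1`: 20200 nM
compound 2 `Cc1nn(-c2ccccc2)c(Oc2ccc(-c3nc4cc([N+](=O)[O-])ccc4[nH]3)cc2)c1/C=N/NC(N)=S`: 6600 nM
compound 3 `COc1ccc(N/N=C/c2c(C)nn(-c3ccccc3)c2Oc2ccc(-c3nc4cc(C(N)=O)ccc4[nH]3)cc2)cc1`: "not determined" (no result reported)

Going by the values given here, all of these results come from a functional assay on HeLa cells (Homo sapiens) for cytotoxicity, read by sulforhodamine B assay, with a stated time of 48 h (a higher number here means a weaker inhibitor of growth, a lower number a stronger inhibitor of growth), and only two of them are numbers. In this assay compound 3 stands at "not determined" (no result reported) and so offers no starting value.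

The next compound is compound 4 `Cc1nn(-c2ccccc2)c(Oc2ccc(-c3nc4cc(C(N)=O)ccc4[nH]3)cc2)c1/C=N/Nc1ccc([N+](=O)[O-])cc1` and it differs from compound 3 by one substituent: nitro in place of methoxy on an aromatic carbon that is, nitro in place of methoxy on an aromatic carbon, para to a large group.

Among the compounds with values here, the only measured step is a 3.1-fold lower number from compound 1 to compound 2 (0.49 log units; beyond the scatter) and it exchanges a group on an amine nitrogen, not a substituent on an aromatic carbon. It therefore bears on this change only loosely. With no value for compound 3 and no measured methoxy-to-nitro swap, no size or direction of step can be expected in this assay here.

The estimate must lean instead on the general range set by compound 1 at 20200 nM and compound 2 at 6600 nM with the wider uncertainty that this brings. Compound 1 is the closer guide, since it too carries an aromatic ring on that amine nitrogen. The expected value for compound 4 is 15000 nM with an estimated range from 4000 nM to 50000 nM in this assay.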

Compound 4, concentration for 50% growth inhibition: 11900 nM
For compound 4 the middle estimate is 1.3-fold (0.10 log units) above the measured one, and the stated range covers the measured number.
By their numbers in this assay, from the lowest: compounds 2, 4 and 1 (each within the scatter of the next, the first and the last beyond it).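

In this assay compound 3 stands at "not determined" (no result reported) and offers no number to compare, so the swap of methoxy for nitro that leads to compound 4 cannot be read as a step. From the compounds shown here alone, what this swap does to growth inhibition stays open. No supporting data bear on the result of compound 4.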